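The source may hold more compounds than are shown below. What is called first, only, known or untested is meant among the compounds shown, and "the series" means these compounds.

The series shares a core that carries an aminophenyl amide on one side and a dithiocarbamate on the other, and differs only in the amine on the thiocarbonyl carbon. In a functional assay on MGC-803 cells (Homo sapiens) for antiproliferative activity, read by CCK-8 assay, with a stated time of 72 h, tested at 2 uM (a higher number here means a stronger effect of the compound at the concentration tested, a lower number a weaker effect), compound 1 `Nc1ccccc1NC(=O)c1ccc(CSC(=S)N2CCc3ccccc32)cc1` gives 44%. Compound 2 `Nc1ccccc1NC(=O)c1ccc(CSC(=S)N2CCc3cc(Cl)ccc32)cc1` gives 57.7% in this assay, a step of a number 13.7 percentage points higher from compound 1 to compound 2 (beyond the scatter). Compound 3 `CCN(Cc1ccncc1)C(=S)SCc1ccc(C(=O)Nc2ccccc2N)cc1` gives 71.6% in this assay, the highest of the three, a step of a number 27.6 percentage points higher from compound 1 to compound 3 (beyond the scatter) and a step of a number 13.9 percentage points higher from compound 2 to compound 3 (beyond the scatter).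

Compound 4 `CC1CCN(C(=S)SCc2ccc(C(=O)Nc3ccccc3N)cc2)CC1` differs from compound 3 in one place: 4-methylpiperidin-1-yl in place of ethyl((pyridin-4-yl)methyl)amino on a thiocarbonyl carbon. Within the data shown here, no measured step brings in a saturated ring amine of this kind; the two steps that bear on the change, a number 27.6 percentage points higher from compound 1 to compound 3 (beyond the scatter) and a number 13.9 percentage points higher from compound 2 to compound 3 (beyond the scatter), show only that the ethyl((pyridin-4-yl)methyl)amino group stood above both dihydroindolyl groups in this assay. Removing that group is therefore expected to lower the number by a modest step, a number 16.6 percentage points lower from compound 3 to compound 4 (beyond the scatter), though with wide uncertainty. Compound 4 is estimated to give 55% in this assay, between 35% and 75%.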

Compound 4, a percentage reported as inhibition, at one concentration (the size of the read-out at that concentration, not a potency): 28.1%
Compound 4: the middle estimate sits 26.9 percentage points above what was measured; measured number below the stated range.
By their numbers in this assay, from the lowest: compound 4; then compound 1; then compound 2; then compound 3.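

In this assay, among these compounds, the 4-methylpiperidin-1-yl group on the thiocarbonyl carbon gives a number 43.5 percentage points lower from compound 3 to compound 4 (beyond the scatter) and so shows that this position can lose far more than the earlier compounds revealed. The same group also falls short of both dihydroindolyl groups, with a number 29.6 percentage points lower from compound 2 to compound 4 (beyond the scatter) and with a number 15.9 percentage points lower from compound 1 to compound 4 (beyond the scatter) as well, so compound 4 is the lowest of the four and the range at this position is wider than compounds 1 to 3 suggested. Nothing available here explains the size of this fall.

The compounds shown leave open whether the pyridin-4-yl ring or the ethyl group of compound 3 matters more to its number. They also leave open where a plain piperidin-1-yl or a morpholin-4-yl group would fall on this carbon.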